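This account rests on a few compounds, and the source may have more. Where it says the series, first, only, none or still open, it means among the compounds named here.

Values in a functional assay on A2780 cells (Homo sapiens) for antiproliferative activity, read by fluorescence, with a stated time of 72 h; a lower number here means a stronger inhibitor, a higher number a weaker inhibitor:
- Compound 1 `CN1CCC(C(=O)N2Cc3c(NC(=O)c4ccsc4)n[nH]c3C2(C)C)CC1`: 140 nM
- Compound 2 `CN1CCC(C(=O)N2Cc3c(NC(=O)c4cccs4)n[nH]c3C2(C)C)CC1`: 30 nM
- Compound 3 `CN1CCC(C(=O)N2Cc3c(NC(=O)c4ccc(F)c(F)c4)n[nH]c3C2(C)C)CC1`: not yet measured

Among the compounds with values here, compound 2 has the lower of the two numbers, and the one measured step is a 4.7-fold lower number from compound 1 to compound 2 (0.67 log units; beyond the scatter). Within the data shown here, that modest step, thiophen-2-yl in place of thiophen-3-yl on a carbonyl carbon, is the only evidence at this place. Compound 3 changes the same place: 3,4-difluorophenyl in place of thiophen-2-yl on a carbonyl carbon. No six-membered ring has been measured here, so the direction is uncertain. A modest step toward a higher number in this assay is expected, namely a 2.0-fold higher number from compound 2 to compound 3 (0.30 log units; within the scatter). For compound 3 the estimated value is 60 nM, with an expected range of 20 nM to 200 nM.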

Compound 3, half-maximal inhibitory concentration in the A2780 assay: 100 nM
For compound 3 the middle estimate is 1.7-fold (0.22 log units) below the measured one, within the range that was stated.
By their numbers in the A2780 assay, from the lowest: compound 2; then compounds 3 and 1 (each within the scatter of the next).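

In the A2780 assay, the first six-membered ring at this place gives a 3.3-fold higher number from compound 2 to compound 3 (0.52 log units; beyond the scatter), and against the other thiophene it gives a 1.4-fold lower number from compound 1 to compound 3 (0.15 log units; within the scatter), so thiophen-2-yl remains set apart from both other groups. In a physicochemical assay for solubility, at pH 7 (a lower number here means a less soluble compound, a higher number a more soluble compound), compound 2 gives 155000 nM. In the physicochemical assay, compound 3 gives > 225000 nM, which is a limit of the assay and not a number: the limit of > 225000 nM in the physicochemical assay, at which 1 of the 2 values shown sits. Read against that limit, the physicochemical assay shows an at least 1.4-fold higher number from compound 2 to compound 3 (0.16 log units; that floor lies within the scatter), so no difference between these two compounds can be claimed there.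

Open, on these data alone, is how an unsubstituted phenyl, a phenyl carrying a single fluorine, or a furan-2-yl on this carbonyl carbon would compare in the A2780 assay.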